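Swapping the Aryl Amide Cap on a Triazole Chain

A few compounds are considered here, and "the series" means these few. Any claim that something is new, unique, unknown or untested is made for them only; others in the source may bear on it.

Compound 1 `Cn1c(Cc2nn(C)c(=O)c3ccccc23)nnc1SCCCCCCCC(=O)Nc1ccc(O)cc1`: > 30000 nM
Compound 2 `Cn1c(Cc2nn(C)c(=O)c3ccccc23)nnc1SCCCCCCCC(=O)Nc1ccc(Br)cc1Br`: 1500 nM

Of the compounds shown here, two sharing one core have been tested in an assay on isolated protein (Mus musculus) for inhibition of IL15-IL15 receptor (Homo sapiens), read by resazurin assay, with stated times of 30 min and 2.5 days; on this read-out lower numbers stand for stronger inhibition and higher numbers for weaker inhibition. Compound 1 gives > 30000 nM, which is a limit of the assay and not a number. Compound 2 gives 1500 nM, the only number shown. The step of an at least 20-fold lower number from compound 1 to compound 2 (1.30 log units; beyond the scatter) corresponds to 2,4-dibromophenyl in place of 4-hydroxyphenyl on an amide-type nitrogen.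

Compound 3 `Cc1ccc(NC(=O)CCCCCCCSc2nnc(Cc3nn(C)c(=O)c4ccccc34)n2C)c(Cl)c1` has not yet been measured. It differs from compound 2 in this way: 2-chloro-4-methylphenyl in place of 2,4-dibromophenyl on an amide-type nitrogen. Within the data shown here, the single measured step concerns a different exchange, so it offers only indirect guidance; the new group keeps a halogen on the ring and adds a methyl. The expected step of a 1.7-fold higher number from compound 2 to compound 3 (0.22 log units; within the scatter) is therefore small and within the scatter. Compound 3 is estimated at 2500 nM, with a range from 800 nM to 8000 nM.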

Compound 3, half-maximal inhibitory concentration: 2300 nM
Compound 3: middle estimate off by 1.1-fold (0.04 log units), on the high side; low and high end bracket the measured number.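

In this assay, replacing 2,4-dibromophenyl with 2-chloro-4-methylphenyl on the amide-type nitrogen gives a 1.5-fold higher number from compound 2 to compound 3 (0.19 log units; within the scatter), so the two caps cannot be ranked and the bromines can both be given up at this position without a change beyond the scatter. The new cap also shows an at least 13-fold lower number from compound 1 to compound 3 (1.11 log units; beyond the scatter), so the large difference from the 4-hydroxyphenyl cap is not tied to 2,4-dibromophenyl alone. The value of compound 1 is a limit of the assay and not a number: the limit of > 30000 nM in this assay, at which 1 of the 3 values shown sits.

On these data alone, it remains open what a plain phenyl cap or a phenyl carrying a carboxylic acid would give, and so whether a halogen on the ring is needed at all. As far as these compounds go, how a shorter chain would read with either active cap is also open.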